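This account rests on a few compounds, and the source may have more. Where it says the series, first, only, none or still open, it means among the compounds named here.

Measured compounds in a functional assay on MCF7 cells (Homo sapiens) for inhibition; on this read-out higher numbers stand for weaker inhibition and lower numbers for stronger inhibition:
Compound 1 `CC/C(=C(/c1ccc(/C=C/C(=O)O)cc1)c1cc2ccccc2[nH]1)c1ccccc1C` — compound 1 gives 33 nM
Compound 2 `CC/C(=C(/c1ccc(/C=C/C(=O)O)cc1)c1cc2ccccc2[nH]1)c1ccc(C#N)cc1` — compound 2 gives 278 nM
Compound 3 `CC/C(=C(/c1ccc(/C=C/C(=O)O)cc1)c1cc2ccccc2[nH]1)c1cccc(Cl)c1Cl` — compound 3 gives 898 nM

Among these three, compound 3 stands at the highest number, the weakest inhibitor of the set: its nearest neighbour is compound 2, with a 3.2-fold higher number from compound 2 to compound 3 (0.51 log units; beyond the scatter) separating them, and its furthest is compound 1, with a 27-fold higher number from compound 1 to compound 3 (1.43 log units; beyond the scatter) between them. Both steps lie beyond the scatter, so compound 3 is clearly the weakest of the three measured.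

Compound 4 `CC/C(=C(/c1ccc(/C=C/C(=O)O)cc1)c1cc2ccccc2[nH]1)c1ccc(Cl)c(C)c1` has not yet been measured in this assay. It differs from compound 3 in one place: 4-chloro-3-methylphenyl in place of 2,3-dichlorophenyl on a double-bonded chain carbon bound to a double-bonded chain carbon and a saturated chain carbon

Among the measured compounds shown here, two measured steps bear on this change, both ending at the same 2,3-dichlorophenyl group that now leaves: the step from the 2-methylphenyl of compound 1, a 27-fold higher number from compound 1 to compound 3 (1.43 log units; beyond the scatter), and the step from the 4-cyanophenyl of compound 2, a 3.2-fold higher number from compound 2 to compound 3 (0.51 log units; beyond the scatter). The entering 4-chloro-3-methylphenyl carries one chlorine and one methyl, so compound 4 is expected to fall somewhere between compound 1 and compound 3, with a lower number than compound 3 and a step of a 4.5-fold lower number from compound 3 to compound 4 (0.65 log units; beyond the scatter). On this basis compound 4 is estimated at 200 nM, with a range from 50 nM to 800 nM.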

Compound 4, half-maximal inhibitory concentration: 840 nM
The estimate for compound 4 lay 4.2-fold (0.62 log units) below the measured number, outside the stated range (above it).
By their numbers in this assay, from the lowest: compound 1; then compound 2; then compounds 4 and 3 (each within the scatter of the next).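

In this assay, putting 4-chloro-3-methylphenyl in place of 2,3-dichlorophenyl on the double-bonded chain carbon gives a 1.1-fold lower number from compound 3 to compound 4 (0.03 log units; within the scatter), so these two differently substituted rings cannot be told apart here, even though one chlorine has given way to a methyl and the substituents sit at different ring positions. The other two steps, a 3.0-fold higher number from compound 2 to compound 4 (0.48 log units; beyond the scatter) and a 25-fold higher number from compound 1 to compound 4 (1.41 log units; beyond the scatter), place compound 4 level with compound 3 and show that a methyl on this ring does not by itself bring the number down to that of compound 1, whose 2-methylphenyl remains well ahead of the other three groups shown. Nothing available accounts for this difference between the 2-methylphenyl and the other groups at this position.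

The compounds shown leave open whether the low number of compound 1 depends on the 2-methyl group, since plain phenyl, 2-chlorophenyl and 2-ethylphenyl at this place are not among them. They also leave open how each substituent of compound 4 acts alone, which 3-methylphenyl and 4-chlorophenyl would show.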